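Methoxy in place of bromo across two inert pairs

The compounds below may be only part of what the source reports. "The series", "measured", "known", "first", "only" and "open" are said of these compounds alone.

Compound 1 `Brc1ccc2[nH]c(-c3cn(-c4ccccc4)nc3-c3ccccc3)nc2c1` was examined in an ADME assay on HaCaT cells (Homo sapiens) for cytotoxicity, read by MTT assay, with a stated time of 48 h (on this read-out lower numbers stand for stronger inhibition and higher numbers for weaker inhibition), where compound 1 gives > 50000 nM, a limit of the assay rather than a number. Compound 2 `COc1ccc2[nH]c(-c3cn(-c4ccccc4)nc3-c3ccccc3)nc2c1` carries the change (methoxy in place of bromo on an aromatic carbon). In this assay compound 2 gives > 50000 nM, again a limit. The step that the two limits leave unreadable from compound 1 to compound 2 stays unreadable. Compound 3 `Clc1ccc(-c2nn(-c3ccccc3)cc2-c2nc3cc(Br)ccc3[nH]2)cc1` differs from compound 1 by chloro in place of hydrogen on an aromatic carbon. In this assay compound 3 gives > 50000 nM, also a limit, so the step that the two limits leave unreadable from compound 1 to compound 3 is unreadable as well. Every value shown sits at the limit of > 50000 nM in this assay, at which 3 of the 3 values shown sit.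

Compound 4 `COc1ccc2[nH]c(-c3cn(-c4ccccc4)nc3-c3ccc(Cl)cc3)nc2c1`, not yet measured, differs from compound 3 by methoxy in place of bromo on an aromatic carbon, the same change that compound 2 carries relative to compound 1, at a place described in the same words. Compound 4 is expected to stay at the limit because all three values shown sit at the limit of > 50000 nM in this assay, at which 3 of the 3 values shown sit. The expected step that the limit leaves unreadable from compound 3 to compound 4 rests on that shared limit and on the unreadable step that the two limits leave unreadable from compound 1 to compound 2. Compound 4 is estimated at 100000 nM, with the expected range running from 50000 nM to 300000 nM.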

Compound 4, half-maximal inhibitory concentration: > 50000 nM
Compound 4: no number, only a limit (the forecaster's own chance of this, stated with the estimate: 85%); the middle value does not contradict the limit.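

In this assay compound 4 gives > 50000 nM, a limit of the assay and not a number. No new step can be read between compound 4 and either compound 3 or compound 2. The compounds shown leave open whether methoxy in place of bromo or chloro in place of hydrogen changes this read-out at all.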